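A few compounds are considered here, and "the series" means these few. Any claim that something is new, unique, unknown or untested is made for them only; others in the source may bear on it.

Three compounds have been measured in a functional assay on the whole organism with Rattus norvegicus as the target, in the glucose tolerance test; on this read-out higher numbers stand for an effect only at larger amounts of compound and lower numbers for an effect already at smaller amounts:

compound 1, `CCCCCCC1(C(=O)OC)CO1`, gives 10 mg/kg
compound 2, `CCCCCCCCCCCCCCC1(C(=O)OCC(O)CO)CO1`, gives 5 mg/kg
compound 3, `CCCCCCCCCCCCCCCCCCCCCCC1(C(=O)OC)CO1`, gives 10 mg/kg

All three share a small oxygen-containing ring bearing an ester and a straight saturated chain. Compound 1 carries the shortest chain. Its number is level with that of compound 3, which carries the longest chain by far, and together these two stand highest of the three; compound 2 sits a little lower, but that gap lies within the usual scatter, so no real order among the three can be claimed.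

Compound 4, `CCCCCCCCCCCCC1(C(=O)OC)CO1`, stands between compound 1 and compound 3 in chain length. It differs from compound 1 in one place: hexyl in place of hydrogen on a saturated chain carbon, six bonds along the chain from a saturated ring carbon.

Since a much longer chain in compound 3 left the number unchanged, a step of medium length is expected to do the same, with no change beyond the scatter. The step of no change at the digits printed from compound 1 to compound 4 (within the scatter) is therefore expected to be flat. Compound 4 is estimated at 10 mg/kg, within 5 mg/kg to 20 mg/kg.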

Compound 4, minimum effective dose: 5 mg/kg
Beside the measured number, compound 4's estimate is 2.0-fold (0.30 log units) above it; low and high end bracket the measured number.
By their numbers in this assay, from the lowest: compounds 2, 4, 1 and 3 (each within the scatter of the next).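

In this assay, going by these compounds alone, the change of hexyl in place of hydrogen on a saturated chain carbon, six bonds along the chain from a saturated ring carbon, gives the first step that can be read between two measured compounds: a 2.0-fold lower number from compound 1 to compound 4 (0.30 log units; within the scatter) and so no real change. This position therefore accepts the hexyl extension without a measurable loss, but the step is too small to count as a gain. Nothing measured alongside this step speaks to why the number stays within the scatter.

The compounds shown leave open whether this chain must remain plain saturated carbon, or whether it could also carry an amine or end in a carboxylic acid. They also leave open how a chain interrupted by a phenyl ring would read out in this assay.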